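The source may hold more compounds than are shown below. What is called first, only, known or untested is meant among the compounds shown, and "the series" means these compounds.

Measured so far:
compound 1, `CCCCCCCC/C=C\CCCCCCCC(=O)OC[C@@H](COC)OP(=O)(O)OC[C@H](N)C(=O)O`: 12.9%
compound 2, `C#CCOC[C@H](COC(=O)CCCCCCC/C=C\CCCCCCCC)OP(=O)(O)OC[C@H](N)C(=O)O`: 12.6%
compound 3, `CCCCCCCC/C=C\CCCCCCCC(=O)OC[C@@H](COCCC)OP(=O)(O)OC[C@H](N)C(=O)O`: 12.2%

In an assay on HEK293 cells for agonist activity at probable G-protein coupled receptor 34 (Mus musculus), with a stated time of 1 h (a higher number here means a larger maximal response, a lower number a smaller maximal response), compound 3 stands with the other two: the steps of a number 0.7 percentage points lower from compound 1 to compound 3 (within the scatter) and a number 0.4 percentage points lower from compound 2 to compound 3 (within the scatter) both lie within the scatter, so the three numbers cannot be told apart. Compound 4 is `CCCCCCCC/C=C\CCCCCCCC(=O)OC[C@@H](COCc1ccccc1)OP(=O)(O)OC[C@H](N)C(=O)O`; against compound 3 it carries phenyl in place of ethyl on a saturated chain carbon bound to an oxygen on a saturated carbon. All three measured steps alter this same place, and each stayed within the scatter: a number 0.3 percentage points lower from compound 1 to compound 2 (within the scatter), a number 0.7 percentage points lower from compound 1 to compound 3 (within the scatter) and a number 0.4 percentage points lower from compound 2 to compound 3 (within the scatter). Going by these compounds, none of them brought in an aromatic ring, so that part of compound 4 is untested, but on these data no step beyond the scatter is expected: a number 0.3 percentage points higher from compound 3 to compound 4 (within the scatter). Compound 4 is therefore estimated at 12.5%, with a range of 5% to 22%.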

Compound 4, largest response reached (Emax), in percent of the reference or control that the assay uses: 9.6%
The estimate for compound 4 lay 2.9 percentage points above the measured number, and the stated range covers the measured number.
By their numbers in this assay, from the lowest: compounds 4, 3, 2 and 1 (each within the scatter of the next).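

The first aromatic ring at this place, on a saturated chain carbon bound to an oxygen on a saturated carbon, still leaves every step in this assay within the scatter: a number 2.6 percentage points lower from compound 3 to compound 4 (within the scatter), a number 3 percentage points lower from compound 2 to compound 4 (within the scatter) and a number 3.3 percentage points lower from compound 1 to compound 4 (within the scatter). Phenyl therefore gives a maximal response that cannot be told apart from those of the smaller groups here. Nothing available explains this result. Still open, going by these compounds, is whether an amine, a carboxylic acid or a longer chain at this place would take the response beyond the scatter.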